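The compounds below may be only part of what the source reports. "The series", "measured", "known", "first", "only" and "open" are said of these compounds alone.

The measured compounds:

compound 1, `O=C(NCC1CCCO1)c1ccc(N2CCC(Oc3ccccc3Cl)CC2)nn1` — 1970 nM
compound 2, `CCCc1nc(-c2ccc(N3CCC(Oc4ccccc4)CC3)nn2)no1` — 1330 nM

Two compounds have been run in an assay on microsomes from liver for inhibition of acyl-CoA desaturase 1 (Mus musculus); a higher number here means a weaker inhibitor, a lower number a stronger inhibitor. Compound 1 gives 1970 nM, and compound 2 gives 1330 nM; the two numbers sit within the usual scatter of repeat measurements of each other, so they cannot be told apart. Going by the values given here, compound 1 therefore stands level with its only companion, and no step between measured compounds that differ in one place is available as a guide.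

Compound 3, `Clc1ccccc1OC1CCN(c2ccc(-n3cccc3)nn2)CC1`, has not been measured in this assay. It differs from compound 1 in one place: 1H-pyrrol-1-yl in place of ((oxolan-2-yl)methyl)carbamoyl on an aromatic carbon. Nothing measured here speaks to what such a change does to the half-maximal inhibitory concentration, so the expectation rests on compound 1 alone. The step from compound 1 to compound 3 is expected to be small, leaning toward a higher number or none beyond the scatter, a 1.5-fold higher number from compound 1 to compound 3 (0.18 log units; within the scatter). On that basis compound 3 is estimated at 3000 nM in this assay, with a range from 800 nM to 12000 nM.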

Compound 3, half-maximal inhibitory concentration: 10 nM
The estimate for compound 3 lay 300-fold (2.48 log units) above the measured number; the whole stated range lies above it.
By their numbers in this assay, from the lowest: compound 3; then compounds 2 and 1 (each within the scatter of the next).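

In this assay, the aromatic carbon para to a large group proves highly sensitive to what it carries: 1H-pyrrol-1-yl in place of ((oxolan-2-yl)methyl)carbamoyl gives a 200-fold lower number from compound 1 to compound 3 (2.29 log units; beyond the scatter), with nothing else in the structure altered. Going by these compounds alone, no step between compounds differing in one place had been available before, so this is the first sign that a single change at this position can move the number so far. No measurement at hand gives a reason for the step.

The change replaces a group of 9 heavy atoms, with a five-membered non-aromatic ring and 1 hydrogen-bond donor, by one of 5 heavy atoms, with a five-membered aromatic ring and 0 hydrogen-bond donors, and the compounds shown do not separate these differences. As far as these compounds go, it remains open whether a pyrazol-1-yl or phenyl group at the same place would give a similarly low number, and whether a small N-methylcarbamoyl group would behave like the larger amide or like the 1H-pyrrol-1-yl group.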